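A Ring Swap on the Shared Core

The source may report more compounds than this note shows. Statements on the series, on what has been measured and on what is new or still open speak of the compounds shown alone.

Among the compounds with values here, compound 3 `Cc1cc(N2CCCCC2)c(S(C)(=O)=O)cc1C(=O)N=C(N)N` gives 21 nM in a functional assay for inhibition of sodium/hydrogen exchanger (Oryctolagus cuniculus) (a higher number here means a weaker inhibitor, a lower number a stronger inhibitor), the second highest of the three numbers measured so far. Compound 2 `Cc1cc(OC2CCCC2)c(S(C)(=O)=O)cc1C(=O)N=C(N)N` gives 27 nM, and a 1.3-fold lower number from compound 2 to compound 3 (0.11 log units; within the scatter) stays within the scatter, while compound 1 `CCc1cc(C)c(C(=O)N=C(N)N)cc1S(C)(=O)=O` gives 4.8 nM, so a 4.4-fold higher number from compound 1 to compound 3 (0.64 log units; beyond the scatter) lies beyond it. Compound 4 `Cc1cc(Nc2cccc(Cl)c2)c(S(C)(=O)=O)cc1C(=O)N=C(N)N` differs from compound 3 in one place: (3-chlorophenyl)amino in place of piperidin-1-yl on an aromatic carbon. Within the data shown here, the steps that bear on this are all changes at the same aromatic carbon: a 5.6-fold higher number from compound 1 to compound 2 (0.75 log units; beyond the scatter) and a 4.4-fold higher number from compound 1 to compound 3 (0.64 log units; beyond the scatter) were modest, whereas a 1.3-fold lower number from compound 2 to compound 3 (0.11 log units; within the scatter) was within the scatter. Because a 1.3-fold lower number from compound 2 to compound 3 (0.11 log units; within the scatter) showed that one ring-bearing group can replace another with little effect, the expected step is a 1.7-fold higher number from compound 3 to compound 4 (0.22 log units; within the scatter), small and uncertain in direction. Compound 4 is therefore estimated at 35 nM, between 10 nM and 130 nM.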

Compound 4, half-maximal inhibitory concentration: 33 nM
For compound 4 the middle estimate is 1.1-fold (0.03 log units) above the measured one; low and high end bracket the measured number.
By their numbers in this assay, from the lowest: compound 1; then compounds 3, 2 and 4 (each within the scatter of the next).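

At this aromatic carbon, ortho to a methylsulfonyl group, an aromatic ring carrying a chlorine and joined through a hydrogen-bond donor fits the same range as the non-aromatic rings, with a 1.6-fold higher number from compound 3 to compound 4 (0.20 log units; within the scatter) and a 1.2-fold higher number from compound 2 to compound 4 (0.09 log units; within the scatter) both small. All three ring-bearing groups stay apart from the ethyl group of compound 1, here with a 6.9-fold higher number from compound 1 to compound 4 (0.84 log units; beyond the scatter) as the step. Nothing measured here explains why these different groups give such similar numbers.

The compounds shown leave open whether a methoxy group or a simple amine at this carbon would give a number nearer that of compound 1, and what the chlorine itself contributes in compound 4.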